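This account rests on a few compounds, and the source may have more. Where it says the series, first, only, none or still open, it means among the compounds named here.

Of the compounds shown here, three have been tested in a functional assay on HEp-2 cells (Homo sapiens) for cytotoxicity, read by MTT assay; on this read-out lower numbers stand for an effect already at smaller amounts and higher numbers for an effect only at larger amounts of compound. Compound 1 `C=C1C(=O)O[C@]2(C)CC[C@@H]1C[C@H](O)[C@@]1(C)CC[C@H](O1)[C@](C)(O)CC[C@H]2OC(C)=O` and compound 2 `C=C1C(=O)O[C@]2(C)CC[C@@H]1C[C@H](O)[C@@]1(C)CC[C@H](O1)[C@](C)(O)CC[C@H]2O` share one core and differ only by acetyl in place of hydrogen on an oxygen on a saturated carbon. Compound 3 `C=C1C(=O)O[C@]2(C)CC[C@@H]1C[C@H](O)[C@@]1(C)CC[C@H](O1)C(=C)CC[C@H]2OC(C)=O` rests on a different core, and the difference between the core of compound 3 and the core of compound 2 is not broken down here. In this assay compound 1 reaches only a limit, < 20 ug/mL. Compound 2 likewise gives only a limit, < 20 ug/mL. Compound 3 is also reported only as a limit, < 20 ug/mL. The step that the two limits leave unreadable from compound 2 to compound 1 can therefore not be sized, since both of its ends sit at the limit of < 20 ug/mL in this assay, at which 3 of the 3 values shown sit.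

The compound not yet measured, compound 4 `C=C1C(=O)O[C@]2(C)CC[C@@H]1C[C@H](OC(C)=O)[C@@]1(C)CC[C@H](O1)C(=C)CC[C@H]2OC(C)=O`, differs from compound 3 by acetyl in place of hydrogen on an oxygen on a saturated carbon, the same change that separates compound 1 from compound 2; among the four compounds this change occurs twice. Going by the values given here, the first instance of the change, a step that the two limits leave unreadable from compound 2 to compound 1, gives no readable size, and every value so far sits at the limit of < 20 ug/mL in this assay, at which 3 of the 3 values shown sit. On that rests the expectation for compound 4: the expected step is a step that the limit leaves unreadable from compound 3 to compound 4, small and uncertain. Compound 4 is thus estimated to give about 8 ug/mL in this assay, with the odds favouring another limit rather than a number.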

Compound 4, concentration for half-maximal effect: < 20 ug/mL
Compound 4: only a limit was reported; the forecaster's own chance of this, stated with the estimate: 75%; the middle value does not contradict the limit.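

In this assay compound 4 again gives only a limit, < 20 ug/mL. No new step can be read, neither from compound 3 to compound 4 nor anywhere else in the series, and the values shown all stand at one and the same mark: the limit of < 20 ug/mL in this assay, at which 4 of the 4 values shown sit.

The compounds shown leave open what actual value each of the four has, and whether acetyl in place of hydrogen changes the read-out at all.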